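Swapping the Aryl Halide for Dimethylamino in Compound 1

This account rests on a few compounds, and the source may have more. Where it says the series, first, only, none or still open, it means among the compounds named here.

Compound 1 `Cc1nc(NC(=O)c2ccccc2)sc1C(=O)/C=C/c1ccc(Br)cc1` is a cinnamoyl thiazole bearing a 4-bromophenyl group. Among the measured compounds shown here, in an assay for inhibition of Polyunsaturated fatty acid 5-lipoxygenase (Homo sapiens), read by spectrophotometry, tested at 10 uM, in the presence of a further agent that is not named here (on this read-out lower numbers stand for less inhibition and higher numbers for more inhibition at the one concentration tested (going by the name of the read-out)), compound 1 gives 52.3%, the lower of the two numbers measured so far. Its companion, compound 2 `COc1cc(/C=C/C(=O)c2sc(NC(=O)c3ccccc3)nc2C)cc(OC)c1OC`, carries a trimethoxyphenyl unit in the same position; in this assay compound 2 gives 100%, a number that lies above that of compound 1 by well more than the scatter of repeated runs. For the measured compounds named here, no pair of compounds differing in one place has been measured, so no step size is established for this series.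

The next compound, compound 3 `Cc1nc(NC(=O)c2ccccc2)sc1C(=O)/C=C/c1ccc(N(C)C)cc1`, differs from compound 1 in one place: dimethylamino in place of bromo on an aromatic carbon. The only hint available is that a different set of substituents on that aromatic ring produces a far higher number than that of compound 1, as compound 2 shows with 100%. On that slender basis, the step from compound 1 to compound 3 is expected to be an increase, a number 12.7 percentage points higher from compound 1 to compound 3 (beyond the scatter), though it could also fall within the scatter. Compound 3 is therefore estimated to give 65% in this assay, within a range from 35% to 95%.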

Compound 3, a percentage reported as inhibition, at one concentration (the size of the read-out at that concentration, not a potency): 88.2%
Beside the measured number, compound 3's estimate is 23.2 percentage points below it, within the range that was stated.
By their numbers in this assay, from the lowest: compound 1; then compound 3; then compound 2.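

In this assay, the replacement of bromo by dimethylamino on this aromatic carbon gives the series its first step from a change in one place: a number 35.9 percentage points higher from compound 1 to compound 3 (beyond the scatter). This shows that a single substituent at this position, with the rest of compound 1 held fixed, can move the read-out by a large amount, which the earlier pair could not show, as compound 1 and compound 2 differ by more than one substituent on that ring. No measurement given here bears on what lies behind the step, so it stands as an observation without an explanation.

As far as these compounds go, it remains open whether the rise is particular to dimethylamino or would also appear with other groups at this position, such as a primary amine, a pyrrolidine or a morpholine, or with a hydroxyl group or a plain hydrogen. Also open, from the compounds shown here alone, is whether the same change would give a step of similar size on a compound in which the benzamide part of the shared core carried a different group, for example a carboxylic acid.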